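Removing the Acetyl from Compound 2: Expected Cytotoxicity

The source may hold more compounds than are shown below. What is called first, only, known or untested is meant among the compounds shown, and "the series" means these compounds.

Compound 2 `CC(=O)Nc1ccc2oc(-c3cccc(F)c3)c(O)c(=O)c2c1` and compound 1 `COc1cccc(-c2oc3ccc(NC(C)=O)cc3c(=O)c2O)c1` share one core and differ only in the group on the aromatic carbon. In an ADME assay on MT4 cells (Homo sapiens) for cytotoxicity, read by MTT assay, with a stated time of 4 days (on this read-out higher numbers stand for lower toxicity in this test and lower numbers for higher toxicity in this test), compound 1 gives 33300 nM, and compound 2 gives 26500 nM. The step of a 1.3-fold lower number from compound 1 to compound 2 (0.10 log units; within the scatter) is small, so compound 2 holds the lower of the two numbers without standing apart from compound 1. Compound 3 `Nc1ccc2oc(-c3cccc(F)c3)c(O)c(=O)c2c1` differs from compound 2 in a single place: hydrogen in place of acetyl on a nitrogen on an aromatic ring. Among the measured compounds shown here, no measured step touches this nitrogen; the only step in hand, from compound 1 to compound 2, concerns a different group, so it gives no direct guidance for the loss of the acetyl. With nothing to suggest a shift in either direction, the expected step of a 1.1-fold lower number from compound 2 to compound 3 (0.03 log units; within the scatter) is none beyond the scatter. Compound 3 is therefore estimated at 25000 nM, within a range of 8000 nM to 80000 nM.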

Compound 3, half-maximal cytotoxic concentration: 35300 nM
Beside the measured number, compound 3's estimate is 1.4-fold (0.15 log units) below it; low and high end bracket the measured number.
By their numbers in this assay, from the lowest: compounds 2, 1 and 3 (each within the scatter of the next).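

In this assay, among the compounds shown here, the exchange of acetamido for amino gives a 1.3-fold higher number from compound 2 to compound 3 (0.12 log units; within the scatter), the first reading at this nitrogen on an aromatic ring. With the fluoro group in place, the acetyl can therefore be replaced by hydrogen on this nitrogen with no difference that this test separates from the usual scatter, so the free amino group and the acetamido group read alike here. Nothing available accounts for this result.

From the compounds shown here alone, this rests on a single pair, so it remains open whether the same holds with methoxy in place of fluoro on the aromatic carbon. Also open, going by these compounds, is how a longer acyl chain such as butanoyl, a methanesulfonyl group or a carboxylic acid on this nitrogen would read in this assay.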